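Microsomal stability in the series: the step to compound 4

This account rests on a few compounds, and the source may have more. Where it says the series, first, only, none or still open, it means among the compounds named here.

Measured compounds in an ADME assay on microsomes from liver (Homo sapiens) for metabolic stability, read by LC-MS, with NADPH named in the record, with a stated time of 60 min, tested at 1 uM, in the absence of a further agent; a lower number here means that less of the compound is left, a higher number that more of the compound is left:
Compound 1 `COc1ccc(-c2c(C)nc3c(N4CC[C@@H](NC(=O)OCc5ccccc5)C4)cc(C)nn23)cc1OC`: in this assay compound 1 gives > 95%, which is a limit of the assay.
Compound 2 `COc1ccc(-c2c(C)nc3c(N4CC[C@@H](NC(=O)Oc5cccc(C)c5)C4)cc(C)nn23)cc1OC`: in this assay compound 2 gives > 95%, which is a limit of the assay.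
Compound 3 `COc1ccc(-c2c(C)nc3c(N4CC[C@@H](NS(=O)(=O)c5ccc(C)cc5)C4)cc(C)nn23)cc1OC`: in this assay compound 3 gives > 95%, which is a limit of the assay.

Compound 3 therefore stands at the upper edge of what this assay reports, together with the other two values (the limit of > 95% in this assay, at which 3 of the 3 values shown sit). The steps a step that the two limits leave unreadable from compound 1 to compound 2, a step that the two limits leave unreadable from compound 1 to compound 3 and a step that the two limits leave unreadable from compound 2 to compound 3 cannot be sized because of the limit of > 95% in this assay, at which 3 of the 3 values shown sit; they show only that exchanging the carbamate or sulfonamide substituent on the saturated ring carbon kept every compound at the limit.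

Compound 4 `COc1ccc(-c2c(C)nc3c(N4CC[C@@H](SC(C)=O)C4)cc(C)nn23)cc1OC` departs further: acetylsulfanyl in place of ((4-methylphenyl)sulfonyl)amino on a saturated ring carbon. Within the data shown here, no measured step touches an acetylsulfanyl group, and none is readable, so the measured steps give no size to expect in this assay. Compound 4 is expected to give 60%, estimated between 20% and 95%. The step of a number at least 35 percentage points lower from compound 3 to compound 4 (beyond the scatter) is expected to point downward.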

Compound 4, percent of the compound remaining: > 95%
Compound 4 ended at the assay's limit; the forecaster's own chance of this, stated with the estimate: 30%; middle value at least 35 percentage points away from the limit.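

The steps from compound 1, compound 2 and compound 3 to compound 4 cannot be read, because all four compounds sit at the same limit: the limit of > 95% in this assay, at which 4 of the 4 values shown sit.

The compounds shown leave open whether any of these groups on the saturated ring carbon changes the percent of compound remaining, as no value shown lies off that limit.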